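The source may report more compounds than this note shows. Statements on the series, on what has been measured and on what is new or still open speak of the compounds shown alone.

Measured in a functional assay on HT-29 cells (Homo sapiens); a higher number here means a weaker inhibitor of growth, a lower number a stronger inhibitor of growth:
Compound 1 `O=S(=O)(/C=C/c1ccc(F)cc1Cl)Cc1ccc(Nc2ncnc3ccccc23)cc1`: 100000 nM
Compound 2 `O=S(=O)(/C=C/c1ccc(Cl)cc1Cl)Cc1ccc(Nc2ncnc3cc(Cl)ccc23)cc1`: 59000 nM
Compound 3 `O=S(=O)(/C=C/c1ccc(C(F)(F)F)cc1F)Cc1ccc(Nc2ncnc3cc(Cl)ccc23)cc1`: > 100000 nM, a limit and not a number

Compound 3 has no number of its own, only (the limit of > 100000 nM in this assay, at which 1 of the 3 values shown sits). Compound 4 `O=S(=O)(/C=C/c1ccc(F)cc1Cl)Cc1ccc(Nc2ncnc3cc(Cl)ccc23)cc1`, not yet measured, differs from it as follows: 2-chloro-4-fluorophenyl in place of 2-fluoro-4-(trifluoromethyl)phenyl on a double-bonded chain carbon bound to a double-bonded chain carbon. Going by the values given here, one measured step bears on this change, an at least 1.6-fold higher number from compound 2 to compound 3 (0.22 log units; that floor lies within the scatter), and it gives only a floor. Compound 1 already carries 2-chloro-4-fluorophenyl and gives 100000 nM. Compound 2 gives 59000 nM. On the strength of these two values, a modest move toward a lower number is expected, estimated as an at least 1.4-fold lower number from compound 3 to compound 4 (0.15 log units; that floor lies within the scatter). The expected value for compound 4 is 70000 nM, with an estimated range of 35000 nM to 140000 nM.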

Compound 4, concentration for 50% growth inhibition: > 100000 nM
Compound 4: a limit, no number; the forecaster's own chance of this, stated with the estimate: 35%; middle value at least 1.4-fold (0.15 log units) away from the limit.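

In this assay compound 4 gives > 100000 nM, a limit and not a number. Fluoro in place of chloro on an aromatic carbon gives an at least 1.6-fold higher number from compound 2 to compound 4 (0.22 log units; that floor lies within the scatter), so of the three compounds sharing the core of compound 2, only compound 2 now has a number. The steps linking compound 4 to compound 3 and to compound 1 cannot be read, and the values stop at one ceiling: the limit of > 100000 nM in this assay, at which 2 of the 4 values shown sit.

Still open, as far as these compounds go, is how far compound 3 and compound 4 lie past that limit. Chloro in place of hydrogen on an aromatic carbon gives a number no lower from compound 1 to compound 4 (the limit leaves the size open) and no more can be said of its size.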